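This account rests on a few compounds, and the source may have more. Where it says the series, first, only, none or still open, it means among the compounds named here.

The measured compounds, with their results in a functional assay on DU-145 cells (Homo sapiens) for cytotoxicity, read by MTT assay, with a stated time of 48 h; a higher number here means a weaker inhibitor, a lower number a stronger inhibitor:

compound 1 `O=C1Nc2ccccc2C1(c1c[nH]c2ccc(Cl)cc12)c1c[nH]c2ccc(Cl)cc12` gives 8100 nM
compound 2 `O=C1Nc2ccccc2C1(c1c[nH]c2ccc([N+](=O)[O-])cc12)c1c[nH]c2ccc([N+](=O)[O-])cc12` gives 8000 nM
compound 3 `O=C1Nc2ccc(F)cc2C1(c1c[nH]c2ccc(Cl)cc12)c1c[nH]c2ccc(Cl)cc12` gives 19600 nM

Compound 1 and compound 3 share one core and differ by fluoro in place of hydrogen on an aromatic carbon. This change carries a 2.4-fold higher number from compound 1 to compound 3 (0.38 log units; beyond the scatter), a shift that lies beyond the usual scatter of the measurement. Compound 2 has a different core from compound 1; the difference between the two cores is not broken down here. What the two values show is that compound 1 and compound 2 sit within the scatter of each other in this assay, so no order between them can be read from these numbers.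

Compound 4 `O=C1Nc2ccc(F)cc2C1(c1c[nH]c2ccc([N+](=O)[O-])cc12)c1c[nH]c2ccc([N+](=O)[O-])cc12` has not yet been measured. It stands to compound 2 as compound 3 stands to compound 1: the change is fluoro in place of hydrogen on an aromatic carbon, and the place description is the same word for word as for the step from compound 1 to compound 3, so this is the same change made on the other core. For the measured compounds named here, the one earlier instance of this change weakened inhibition by a modest amount beyond the scatter. Going by the values given here, because a 2.4-fold higher number from compound 1 to compound 3 (0.38 log units; beyond the scatter) is the only guide available, the expectation for compound 4 is a step of about a 2.4-fold higher number from compound 2 to compound 4 (0.38 log units; beyond the scatter), in the same direction and of similar size. On that basis compound 4 is estimated to give 19000 nM in this assay, with a likely range from 9000 nM to 40000 nM.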

Compound 4, half-maximal inhibitory concentration: 7500 nM
Compound 4: middle estimate off by 2.5-fold (0.40 log units), on the high side; measured number below the stated range.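

For the compounds shown here, on the second core, fluoro in place of hydrogen on an aromatic carbon gives in this assay a result of a 1.1-fold lower number from compound 2 to compound 4 (0.03 log units; within the scatter), so here the change leaves no step that can be read, whereas on the first core it gave a 2.4-fold higher number from compound 1 to compound 3 (0.38 log units; beyond the scatter). Set side by side, the two steps cannot be told apart, and the series therefore gives no firm sign that the second core responds differently from the first: the same change on two cores in this assay, a 2.4-fold higher number (0.38 log units; beyond the scatter) from compound 1 to compound 3 and a 1.1-fold lower number (0.03 log units; within the scatter) from compound 2 to compound 4, 2.6-fold (0.41 log units) apart, within the scatter of two such steps. Going by these compounds alone, this does not show that the change carries over unaltered either, since only one of the two steps lies beyond the scatter, and a single pair on each core can neither establish a shared effect of the fluoro nor tie its effect to the core.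

The compounds shown leave open whether the same change would behave alike on cores carrying an amine, a carboxylic acid or a longer chain in place of the chloro or nitro groups, and whether a further pair on either core would settle the comparison. They also leave open whether chloro, bromo or methyl in place of the fluoro would follow the same course.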